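The compounds below may be only part of what the source reports. "The series", "measured", "known", "first", "only" and "open" are said of these compounds alone.

Measured so far:
- compound 1, `Cc1ncc(-c2ccccc2NCC2=NCCN2)o1`: 110 nM
- compound 2, `Cc1nc(-c2ccccc2NCC2=NCCN2)cs1`: 4.47 nM
- compound 3, `c1csc(-c2ccccc2NCC2=NCCN2)c1`: 2.24 nM

In a functional assay for activation of Alpha-1A adrenergic receptor (Homo sapiens), read by calcium flux (on this read-out higher numbers stand for an effect only at larger amounts of compound and lower numbers for an effect already at smaller amounts), compound 1 gives the highest number of the three measured. The two compounds with a sulfur-containing five-membered ring give numbers far below it: a 25-fold lower number from compound 1 to compound 2 (1.39 log units; beyond the scatter) and a 49-fold lower number from compound 1 to compound 3 (1.69 log units; beyond the scatter). Between those two, a 2.0-fold lower number from compound 2 to compound 3 (0.30 log units; within the scatter), so the two sulfur-containing variants cannot be told apart on these numbers.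

Compound 4, `Cc1ccsc1-c1ccccc1NCC1=NCCN1`, is not yet measured. It differs from compound 1 in one place, (3-methylthiophen-2-yl in place of 2-methyl-1,3-oxazol-5-yl on an aromatic carbon).

Going by the values given here, the steps that bear on it are the two that replace 2-methyl-1,3-oxazol-5-yl on the same aromatic carbon with a sulfur-containing five-membered ring: a 25-fold lower number from compound 1 to compound 2 (1.39 log units; beyond the scatter) and a 49-fold lower number from compound 1 to compound 3 (1.69 log units; beyond the scatter), both large and beyond the scatter. The entering group of compound 4 is a thiophen-2-yl carrying a methyl, so the closest measured analogue is compound 3. Among the compounds with values here, no measured step shows what the added methyl on the thiophene does, which leaves the estimate wider than the gap between compound 2 and compound 3.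

In this assay compound 4 is therefore expected to give a large drop from compound 1, a 34-fold lower number from compound 1 to compound 4 (1.54 log units; beyond the scatter), with the estimate 3.2 nM and a range of 0.8 nM to 13 nM.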

Compound 4, half-maximal effective concentration: 0.851 nM
For compound 4 the middle estimate is 3.8-fold (0.58 log units) above the measured one; the range from low to high includes it.
By their numbers in this assay, from the lowest: compound 4; then compounds 3 and 2 (each within the scatter of the next); then compound 1.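

In this assay, going by these compounds alone, the methyl group on the thiophene now has a step of its own, which no earlier pair could give (a 2.6-fold lower number from compound 3 to compound 4 (0.42 log units; beyond the scatter)); this is methyl in place of hydrogen on an aromatic carbon, modest in size but beyond the scatter. The same group also separates the thiophene series from the thiazole, which compound 3 could not do against compound 2 (a 5.3-fold lower number from compound 2 to compound 4 (0.72 log units; beyond the scatter)). Within the data shown here, of the replacements of 2-methyl-1,3-oxazol-5-yl on this aromatic carbon of the shared core, 3-methylthiophen-2-yl gives the largest step so far (a 130-fold lower number from compound 1 to compound 4 (2.11 log units; beyond the scatter)), and compound 4 now lies beyond the scatter of all three others, with the lowest number of the four.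

The compounds shown leave open whether the gain follows from the methyl alone or would persist with an ethyl group, a methoxy group, an amine or a carboxylic acid in its place on the thiophene. They also leave open what the same methyl would do on the 2-methyl-1,3-oxazol-5-yl or 2-methyl-1,3-thiazol-4-yl rings.

Nothing available explains any of these steps.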